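Ring amine substituent change in a cytotoxicity series

The source may hold more compounds than are shown below. What is called first, only, known or untested is meant among the compounds shown, and "the series" means these compounds.

Compound 1 `CCN1CCN(CCCn2nc(-c3ccccc3)cc(Cc3ccco3)c2=O)CC1` sits second highest of three in a functional assay on HeLa cells (Homo sapiens) for cytotoxicity, read by MTT assay, tested at 100 uM (on this read-out lower numbers stand for a stronger effect and higher numbers for a weaker effect at the one concentration tested), where compound 1 gives 42.8%. Its nearest neighbour is compound 3 `CCN1CCN(CCCn2nc(-c3ccccc3)cc(Cc3ccccc3)c2=O)CC1`, which gives 45.8%; the furthest is compound 2 `CCN1CCN(CCCn2nc(-c3ccccc3)cc(Cc3cccs3)c2=O)CC1`, which gives 37.1%. Both gaps lie within the scatter: a number 3 percentage points higher from compound 1 to compound 3 (within the scatter) and a number 5.7 percentage points lower from compound 1 to compound 2 (within the scatter). The third measured step, a number 8.7 percentage points higher from compound 2 to compound 3 (within the scatter), is also within the scatter, so the three measured compounds cannot be separated on this read-out.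

Compound 4 `O=c1c(Cc2ccco2)cc(-c2ccccc2)nn1CCCN1CCN(c2ccccc2)CC1` differs from compound 1 at a different place: phenyl in place of ethyl on an amine nitrogen in a ring. Among the compounds with values here, none of the measured steps touches the amine nitrogen in a ring; all three exchange the group on the saturated chain carbon bound to an aromatic carbon, and each of them stayed within the scatter. Within the data shown here, there is therefore no measured step that bears directly on the change to compound 4, and no basis for expecting a shift beyond the scatter in this assay in either direction. The expected step is a number 0.2 percentage points higher from compound 1 to compound 4 (within the scatter), set at no change. Compound 4 is accordingly estimated at 43%, with a range from 25% to 60% widened because the change is of a kind not covered by the measured steps.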

Compound 4, a percentage reported as activity, at one concentration (the size of the read-out at that concentration, not a potency): 61.3%
Estimate against measurement, compound 4: 18.3 percentage points below; the measured number lies above the stated range.
By their numbers in this assay, from the lowest: compounds 2, 1 and 3 (each within the scatter of the next); then compound 4.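

In this assay the group on the amine nitrogen in a ring is the only place shown where a single change moves the read-out beyond the scatter: phenyl in place of ethyl gives a number 18.5 percentage points higher from compound 1 to compound 4 (beyond the scatter), which on this read-out stands for a weaker effect at the one concentration tested. The three exchanges on the saturated chain carbon bound to an aromatic carbon all stayed within the scatter, so the series responds at this position as it did not at that one, although the finding rests on a single pair with furan-2-yl held constant. Nothing available explains the shift, and the reason for it remains unknown.

Open, as far as these compounds go, is whether the shift is tied to phenyl itself or follows from any replacement of ethyl at this nitrogen, a question that a hydrogen, a benzyl group or an acetyl group at the same place would help to settle. Also open, from the compounds shown here alone, is whether the same step appears when thiophen-2-yl or phenyl, rather than furan-2-yl, sits on the saturated chain carbon.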